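Ethynyl for 1-benzofuran-2-yl: compound 3 to compound 4

A few compounds are considered here, and "the series" means these few. Any claim that something is new, unique, unknown or untested is made for them only; others in the source may bear on it.

Compound 3 (`CN(C)c1ncnc2c1c(-c1cc3ccccc3o1)cn2[C@@H]1O[C@H](CO)[C@@H](O)[C@H]1O`) gives > 20000 nM in a functional assay on HCT-116 cells (Homo sapiens), read by MTT assay, with a stated time of 72 h (on this read-out higher numbers stand for weaker inhibition and lower numbers for stronger inhibition), as a limit and not a number. Compound 2 (`CN(C)c1ncnc2c1c(-c1ccsc1)cn2[C@@H]1O[C@H](CO)[C@@H](O)[C@H]1O`) gives > 20000 nM as a limit too. Compound 3 therefore sits with compound 2 at the limit of > 20000 nM in this assay, at which 2 of the 3 values shown sit, on this scale. Compound 4 (`C#Cc1cn([C@@H]2O[C@H](CO)[C@@H](O)[C@H]2O)c2ncnc(N(C)C)c12`) carries ethynyl in place of 1-benzofuran-2-yl on an aromatic carbon on the same aromatic carbon. Among the measured compounds shown here, the one measured step, a step that the two limits leave unreadable from compound 2 to compound 3, gives no size to work from. Compound 1 (`C#Cc1cn([C@@H]2O[C@H](CO)[C@@H](O)[C@H]2O)c2ncnc(OC)c12`) also holds ethynyl, though the core of compound 1 differs elsewhere, and compound 1 reads 5140 nM in this assay as a true number. On that value, the estimated step of an at least 2.5-fold lower number from compound 3 to compound 4 (0.39 log units; beyond the scatter) is expected towards stronger inhibition, with wide uncertainty. For compound 4 the estimate is 8000 nM with an expected range from 2000 nM to 20000 nM in this assay.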

Compound 4, half-maximal inhibitory concentration: 290 nM
Beside the measured number, compound 4's estimate is 28-fold (1.44 log units) above it; measured number below the stated range.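

In this assay, ethynyl on this aromatic carbon gives an at least 68-fold lower number from compound 3 to compound 4 (1.83 log units; beyond the scatter) in place of 1-benzofuran-2-yl, and an at least 68-fold lower number from compound 2 to compound 4 (1.83 log units; beyond the scatter) in place of thiophen-3-yl, so this position does respond to its substituent. With ethynyl held, the group on the other aromatic carbon also counts: dimethylamino in place of methoxy gives an 18-fold lower number from compound 1 to compound 4 (1.25 log units; beyond the scatter). The two aromatic substituents remain a limit and not a number: the limit of > 20000 nM in this assay, at which 2 of the 4 values shown sit.

As far as these compounds go, whether the effect needs the triple bond stays open. A nitrile or a propynyl group on the same carbon, with dimethylamino held, would address this.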